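Changing the aryl group on an amide-type nitrogen

A few compounds are considered here, and "the series" means these few. Any claim that something is new, unique, unknown or untested is made for them only; others in the source may bear on it.

Two compounds share a common core and differ only in the aryl group carried on an amide-type nitrogen. Compound 1 `O=C(Nc1cccc(CNc2nccnc2Cl)c1)Nc1ccc(F)c(Cl)c1` gives 5020 nM in a functional assay on MGC-803 cells (Homo sapiens) for antiproliferative activity, read by MTT assay, with a stated time of 48 h; on this read-out higher numbers stand for weaker inhibition and lower numbers for stronger inhibition. Compound 2 `CC(C)(C)c1ccc(NC(=O)Nc2cccc(CNc3nccnc3Cl)c2)cc1` gives 4820 nM in the same test. Compound 1 has the higher of the two numbers, but the gap to compound 2 is within the scatter, so the two values cannot be told apart.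

Compound 3 `O=C(Nc1cccc(CNc2nccnc2Cl)c1)Nc1ccc(Cl)cc1Br` has not been measured. Relative to compound 1 the change is 2-bromo-4-chlorophenyl in place of 3-chloro-4-fluorophenyl on an amide-type nitrogen. The aryl group that leaves and the one that enters have the same heavy-atom count and neither carries a hydrogen-bond donor or acceptor; only the halogens and their positions differ.

Nothing measured here shows how this assay responds to moving or exchanging halogens on this group. The two measured compounds, with quite different aryl groups, give near-identical numbers, so no step beyond the scatter is expected from compound 1 to compound 3. Compound 3 is expected to give 5500 nM, within 2000 nM to 15000 nM, which means an expected step of a 1.1-fold higher number from compound 1 to compound 3 (0.04 log units; within the scatter).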

Compound 3, half-maximal inhibitory concentration: 7480 nM
For compound 3 the middle estimate is 1.4-fold (0.13 log units) below the measured one; the measured number falls inside the stated range.
By their numbers in this assay, from the lowest: compounds 2, 1 and 3 (each within the scatter of the next).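

In this assay, exchanging 3-chloro-4-fluorophenyl for 2-bromo-4-chlorophenyl on an amide-type nitrogen amounts to a 1.5-fold higher number from compound 1 to compound 3 (0.17 log units; within the scatter). Among the compounds shown here, this is the first comparison in which only the halogens and their places on the phenyl ring differ, with the heavy-atom count unchanged, and compound 1 and compound 3 cannot be told apart. At this place, then, replacing fluorine with bromine and rearranging the halogens together leaves the number within the scatter, and no information on what lies behind this result is available.

The identity of the halogens and their places on the ring change together here, so the contribution of each remains unresolved, as does the effect of a single bromine or chlorine on the phenyl ring. All three compounds give similar numbers in this assay, which leaves open whether an aryl group carrying an amine or a carboxylic acid, or a pyridine ring in place of the phenyl ring, would produce a step beyond the scatter.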